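The source may report more compounds than this note shows. Statements on the series, on what has been measured and on what is new or still open speak of the compounds shown alone.

Compound 1 `O=C(CCCCC1CCSS1)Nc1cccc(C(F)(F)F)c1` and compound 2 `O=C(CCCCC1CCSS1)Nc1cccc2ccccc12` share an amide-linked ring-bearing side chain but carry different aromatic cores; the difference between the two cores is not broken down here. In a functional assay on KB cells (Homo sapiens) for inhibition, read by MTT assay, with a stated time of 24 h, tested at 10 ug/mL (a higher number here means more inhibition of growth at the concentration tested, a lower number less inhibition of growth), compound 1 gives 10.9%, while compound 2 was reported only as "not active" (no number reported), without a number. Compound 3 `O=C(CCCCC(S)CCS)Nc1cccc(C(F)(F)F)c1` arises from compound 1 by a group of 5 heavy atoms (3 carbon, 2 sulfur; no ring) in place of a group of 5 heavy atoms (3 carbon, 2 sulfur; one five-membered non-aromatic ring with 2 hetero atoms), on a saturated chain carbon, four bonds along the chain from a carbonyl carbon a number 8.9 percentage points lower from compound 1 to compound 3 (within the scatter). Compound 4 `O=C(CCCCC(S)CCS)Nc1cccc2ccccc12` arises from compound 2 by the same change, (a group of 5 heavy atoms (3 carbon, 2 sulfur; no ring) in place of a group of 5 heavy atoms (3 carbon, 2 sulfur; one five-membered non-aromatic ring with 2 hetero atoms), on a saturated chain carbon, four bonds along the chain from a carbonyl carbon). In this assay compound 3 gives 1.97%. For compound 4 a step of similar size is expected in this assay because a number 8.9 percentage points lower from compound 1 to compound 3 (within the scatter) stays within the scatter, and compound 2 offers no number from which a larger move could be traced. Compound 4 is therefore estimated to give 3%, plausibly between 0% and 12%.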

Compound 4, percent growth inhibition at one concentration: "not active" (no number reported)
The entry for compound 4 holds no number; the estimate stays without a comparison.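

Compound 2 and compound 4 are both reported only as not active in this assay, so no new step can be read between them. No evidence bears on this result. The compounds shown leave open whether the 1,3-disulfanylpropyl group, in place of the ring, shifts growth inhibition on the core of compound 2.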